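Working notes on the amide series: compound 3 to compound 4

The source may hold more compounds than are shown below. What is called first, only, known or untested is meant among the compounds shown, and "the series" means these compounds.

Compound 3 `CCCOCC(=O)Nc1cc2nc(C3CCCCC3)[nH]c2cc1N1CCCC1` is one of three measured amides on the shared core. In an ADME assay on Vero cells (Chlorocebus sabaeus) for cytotoxicity, read by resazurin assay, with a stated time of 3 days (a lower number here means a stronger inhibitor, a higher number a weaker inhibitor), compound 3 gives > 100 ug/mL, which is a limit of the assay and not a number. Compound 1 `CCCCCC(=O)Nc1cc2nc(C3CCCCC3)[nH]c2cc1N1CCCC1` gives in this assay > 100 ug/mL, likewise a limit. Compound 2 `O=C(Nc1cc2nc(C3CCCCC3)[nH]c2cc1N1CCCC1)c1ccc(Br)cc1` gives > 100 ug/mL, again a limit. All three values sit at the limit of > 100 ug/mL in this assay, at which 3 of the 3 values shown sit, so the steps a step that the two limits leave unreadable from compound 1 to compound 2, a step that the two limits leave unreadable from compound 1 to compound 3 and a step that the two limits leave unreadable from compound 2 to compound 3 cannot be sized; compound 3 stands where the other two stand, at the limit.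

Compound 4 `O=C(Nc1cc2nc(C3CCCCC3)[nH]c2cc1N1CCCC1)c1ccccc1` differs from compound 3 by phenyl in place of propoxymethyl on a carbonyl carbon. Within the data shown here, the measured step nearest to this change is the one from compound 2 to compound 3, which exchanges 4-bromophenyl for propoxymethyl on the carbonyl carbon; both of its ends are limits, so it gives no readable size. On that basis the step that the limit leaves unreadable from compound 3 to compound 4 is expected to be none beyond the scatter, with the value of compound 4 again reported as a limit. Compound 4 is estimated at 150 ug/mL, within 60 ug/mL to 400 ug/mL.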

Compound 4, half-maximal inhibitory concentration: > 100 ug/mL
Compound 4: no number, only a limit (the forecaster's own chance of this, stated with the estimate: 85%); the middle value is on the limit's open side.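

No step to compound 4 can be read: its comparisons with compound 1, compound 2 and compound 3 all join limits, not numbers, and the series stands at: the limit of > 100 ug/mL in this assay, at which 4 of the 4 values shown sit.

The compounds shown leave open how far each amide lies from that limit, and whether any change on the carbonyl carbon shifts the value.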